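The compounds below may be only part of what the source reports. "The series", "measured", "known", "first", "only" and "open" are said of these compounds alone.

The compounds here share one core, seen in compound 1 `CS(=O)(=O)Oc1c(C(=O)NCc2ccc(F)cc2)nc(Br)c2cccnc12`, and were tested in a functional assay on HCT-116 cells (Homo sapiens) for cytotoxicity, read by MTT assay, with a stated time of 72 h; on this read-out higher numbers stand for weaker inhibition and lower numbers for stronger inhibition. In this assay compound 1 gives only a limit, > 20000 nM, so no single number is known for it, and the limit of > 20000 nM in this assay, at which 1 of the 3 values shown sits, marks where it sits. Two related compounds carry an amino-substituted ring on the same side of the core. Compound 2 `N[C@H]1CC[C@H](Nc2c(C(=O)NCc3ccc(Oc4ccccc4)cc3)nc(Br)c3cccnc23)CC1` has no result in this assay, "not determined" (no result reported). Compound 3 `N[C@H]1CC[C@H](Nc2c(C(=O)NC3CCCCC3)nc(Br)c3cccnc23)CC1` also gives only a limit in this assay, > 10000 nM, and the limit of > 10000 nM in this assay, at which 1 of the 3 values shown sits, marks where that value sits. Of the three values shown, none is a single number, so compound 1 cannot be placed above or below anything.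

Compound 4 `Nc1cccc(Nc2c(C(=O)NCc3ccc(F)cc3)nc(Br)c3cccnc23)c1` differs from compound 1 in one place: (3-aminophenyl)amino in place of (methylsulfonyl)oxy on an aromatic carbon. Going by the values given here, no measured pair of compounds shows what such a change does in this assay, so the expectation rests only on the two limits. The estimated step is an at least 2.5-fold lower number from compound 1 to compound 4 (0.39 log units; beyond the scatter), toward stronger inhibition but with wide uncertainty. Compound 4 is estimated to give 8000 nM, with a range from 1500 nM to 40000 nM, and it is quite possible that this assay again reports only a limit.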

Compound 4, half-maximal inhibitory concentration: > 10000 nM
Compound 4: a limit, no number (the forecaster's own chance of this, stated with the estimate: 50%); middle value at least 1.2-fold (0.09 log units) from the limit.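

In this assay compound 4 gives only a limit, > 10000 nM. Compound 1 also gives only a limit, > 20000 nM, so no step can be read from compound 1 to compound 4. The compounds shown leave open how strongly any of them inhibits and what (3-aminophenyl)amino in place of (methylsulfonyl)oxy actually does in this read-out.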